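Formyl to (pyrrolidin-2-yl)carbonyl on the shared core

A few compounds are considered here, and "the series" means these few. Any claim that something is new, unique, unknown or untested is made for them only; others in the source may bear on it.

Values so far in a functional assay (strain AB) with Danio rerio as the target, read by microscopy, with a stated time of 1 h (on this read-out lower numbers stand for an effect already at smaller amounts and higher numbers for an effect only at larger amounts of compound), for two compounds
- compound 1 `CCN1CCc2c(sc(NC=O)c2C(N)=O)C1` gives > 25000 nM (a limit)
- compound 2 `CCN1CCc2c(sc(NC(=O)Nc3ccc4ccccc4c3)c2C(N)=O)C1` gives 1780 nM as a number

Compound 1 stands at the limit of > 25000 nM in this assay, at which 1 of the 2 values shown sits, and this entry is a limit, not a number. Of the two, only compound 2 returns a number, 1780 nM in this case. The step followed here leads to compound 3 `CCN1CCc2c(sc(NC(=O)[C@@H]3CCCN3)c2C(N)=O)C1` which has not yet been measured. The change (pyrrolidin-2-yl in place of hydrogen on a carbonyl carbon) puts pyrrolidin-2-yl in place of hydrogen on a carbonyl carbon, so formyl becomes (pyrrolidin-2-yl)carbonyl. Going by the values given here, no measured step of this kind exists to size it. Among the compounds with values here, compound 2 at 1780 nM is the only numeric guide, so a modest move toward lower numbers is expected in this assay for this change. The expected size is an at least 2.0-fold lower number from compound 1 to compound 3 (0.31 log units; beyond the scatter) as an estimate only. Compound 3 is expected at 12000 nM within an estimated range of 3000 nM to 40000 nM for now.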

Compound 3, half-maximal effective concentration: > 25000 nM
Compound 3 gave a limit, no number (the forecaster's own chance of this, stated with the estimate: 45%); middle value at least 2.0-fold (0.31 log units) from the limit.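

No step can be read from compound 1 to compound 3 in this assay, because each of the two compounds gives a limit and not a number: the limit of > 25000 nM in this assay, at which 2 of the 3 values shown sit.

The compounds shown leave open how far, if at all, (pyrrolidin-2-yl)carbonyl in place of formyl moves the read-out.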